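Replacing a carboxylic acid chain with a tetrazole ring

The source may hold more compounds than are shown below. What is called first, only, known or untested is meant among the compounds shown, and "the series" means these compounds.

Measured so far:
compound 1, `CC(C)(C)C(=O)CN1C(=O)N(CC(=O)Nc2cccc(-c3nc(=O)o[nH]3)c2)N=C(C2CCCCC2)c2ccccc21`, gives 589 nM in an assay on CHO-K1 cells for displacement of a labelled ligand from Cholecystokinin receptor type A (Homo sapiens); a higher number here means a weaker inhibitor, a lower number a stronger inhibitor.
compound 2, `O=C(O)CSc1cccc(NC(=O)CN2N=C(C3CCCCC3)c3ccccc3N(CC(=O)C3CCCC3)C2=O)c1`, gives 2090 nM in this assay.
compound 3, `CC(C)(C)C(=O)CN1C(=O)N(CC(=O)Nc2cccc(CCC(=O)O)c2)N=C(C2CCCCC2)c2ccccc21`, reaches only the limit of this assay, > 10000 nM.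

Compound 3 thus stands at the weak end of the three; its number is a limit, not a measured value, and it sits at the limit of > 10000 nM in this assay, at which 1 of the 3 values shown sits. Compound 1 and compound 2 both gave proper numbers, with compound 1 the lower of the two.

Compound 4, `CC(C)(C)C(=O)CN1C(=O)N(CC(=O)Nc2cccc(-c3nn[nH]n3)c2)N=C(C2CCCCC2)c2ccccc21`, is not yet measured. It differs from compound 3 in one place: 2H-tetrazol-5-yl in place of 2-carboxyethyl on an aromatic carbon. The change is the reverse kind of move to the one already seen: from compound 1 to compound 3 the five-membered aromatic ring with hetero atoms gave way to an open chain, and the result was an at least 16-fold higher number from compound 1 to compound 3 (1.22 log units; beyond the scatter). Compound 4 brings a five-membered aromatic ring with hetero atoms back onto the same aromatic carbon. A large step toward a lower number is therefore expected for compound 4, namely an at least 16-fold lower number from compound 3 to compound 4 (1.22 log units; beyond the scatter), although the limit for compound 3 leaves the true size open.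

The expected value for compound 4 is 600 nM, within the range 150 nM to 3000 nM.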

Compound 4, inhibition constant: 1740 nM
The estimate for compound 4 lay 2.9-fold (0.46 log units) below the measured number, within the range that was stated.
By their numbers in this assay, from the lowest: compound 1; then compounds 4 and 2 (each within the scatter of the next). At a limit, above all of these: compound 3.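

In this assay, placing 2H-tetrazol-5-yl on this aromatic carbon instead of 2-carboxyethyl gives an at least 5.7-fold lower number from compound 3 to compound 4 (0.75 log units; beyond the scatter), so a second five-membered aromatic ring with hetero atoms also reads better here than the open chain of compound 3. On these data alone, compound 3 has only a limit and not a number, so the full size of this step stays unknown: the limit of > 10000 nM in this assay, at which 1 of the 4 values shown sits. The two rings do not read alike, however: going from the ring with 3 hetero atoms to the one with 4 gives a 3.0-fold higher number from compound 1 to compound 4 (0.47 log units; beyond the scatter) and shows that the identity of the ring matters at this position, not only its presence.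

The compounds shown leave open whether a carboxylic acid set directly on this aromatic carbon, or a shorter carboxymethyl chain, would read more like the rings or more like 2-carboxyethyl, so the effect of the ring cannot yet be separated from that of chain length. They also leave open how an amine would read at this place, and whether the two rings would keep their order with the cyclopentyl ketone side chain of compound 2 in place of the tert-butyl ketone.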